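Changing the Pendant Aryl Group: Compound 2 to Compound 3

This account rests on a few compounds, and the source may have more. Where it says the series, first, only, none or still open, it means among the compounds named here.

Measured compounds:
Compound 1 `COc1ccc(-c2ccc(C(=O)Nc3ccc(Oc4ccnc5[nH]ccc45)c(F)c3)nc2)cc1`: 10100 nM
Compound 2 `CCc1ccc(-c2ccnc(C(=O)Nc3ccc(Oc4ccnc5[nH]ccc45)c(F)c3)c2)cc1`: 7470 nM

In a functional assay on MCF7 cells (Homo sapiens) for cytotoxicity, read by MTT assay, with a stated time of 72 h (a higher number here means a weaker inhibitor, a lower number a stronger inhibitor), compound 1 gives 10100 nM and compound 2 gives 7470 nM. Compound 2 has the lowest of the two numbers, but its nearest neighbour, compound 1, sits within the scatter of it, so no order can be drawn between them.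

Compound 3 `O=C(Nc1ccc(Oc2ccnc3[nH]ccc23)c(F)c1)c1cc(-c2ccc(F)cc2F)ccn1` has not yet been measured in this assay. It differs from compound 2 in one place: 2,4-difluorophenyl in place of 4-ethylphenyl on an aromatic carbon. Among the measured compounds shown here, no step between measured compounds matches this change, so nothing here shows how this assay responds to it. A step no larger than the scatter, in either direction, is expected.

Compound 3 is therefore estimated at 8000 nM, with a range from 2500 nM to 25000 nM. The expected step is a 1.1-fold higher number from compound 2 to compound 3 (0.03 log units; within the scatter).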

Compound 3, half-maximal inhibitory concentration: > 10000 nM
Compound 3: no number, only a limit (the forecaster's own chance of this, stated with the estimate: 10%); middle value at least 1.2-fold (0.09 log units) from the limit.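

In this assay compound 3 gives > 10000 nM, which is a limit of the assay and not a number. Placing 2,4-difluorophenyl in place of 4-ethylphenyl on the aromatic carbon opposite the ring nitrogen gives an at least 1.3-fold higher number from compound 2 to compound 3 (0.12 log units; that floor lies within the scatter), so this change at this position brings no lower number, and only a floor for the step can be read, with its true size unknown. The reading of compound 3 stops at the edge of what the assay reports: the limit of > 10000 nM in this assay, at which 1 of the 3 values shown sits.

The compounds shown leave open how far compound 3 really lies from compound 2, and so whether this position responds to the change at all. As far as these compounds go, whether an amine, a carboxylic acid or a longer chain on the pendant phenyl would move the number here also remains open.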